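Anilide Swap Where Both Measured Anchors Sit at the Limit

This account rests on a few compounds, and the source may have more. Where it says the series, first, only, none or still open, it means among the compounds named here.

Compound 1 `COc1ccc2c(=O)c(/C=C/C(=O)Nc3cccc(C)c3)coc2c1`: > 100000 nM
Compound 2 `COc1ccc2c(=O)c(/C=C/C(=O)Nc3cccc(Cl)c3)coc2c1`: > 100000 nM

Both values in a functional assay (QGY7701 cells, Homo sapiens) for inhibition, read by MTT assay, with a stated time of 48 h (on this read-out higher numbers stand for weaker inhibition and lower numbers for stronger inhibition), are limits of the assay, not numbers, so compound 1 stands only at that limit with no readable number. The step that the two limits leave unreadable from compound 1 to compound 2 is unreadable because both values sit at the limit of > 100000 nM in this assay, at which 2 of the 2 values shown sit.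

Compound 3 `COc1ccc(NC(=O)/C=C/c2coc3cc(OC)ccc3c2=O)cc1` differs from compound 1 by 4-methoxyphenyl in place of 3-methylphenyl on an amide-type nitrogen. Within the data shown here, no measured step bears on this change, and compound 1 gives only a limit, so no direction beyond the scatter can be expected. Compound 3 is expected to give 100000 nM, within 30000 nM to 300000 nM. The step this estimate implies is a number no higher from compound 1 to compound 3 (the limit leaves the size open).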

Compound 3, half-maximal inhibitory concentration: > 100000 nM
Compound 3 was reported as a limit; the forecaster's own chance of this, stated with the estimate: 80%; the middle value sits exactly at the limit.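

Compound 3, like compound 1 and compound 2, gives only a limit in this assay, so no step among the three can be read: the limit of > 100000 nM in this assay, at which 3 of the 3 values shown sit.

The compounds shown leave open whether any of these groups on the amide-type nitrogen changes inhibition at all.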